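The source may hold more compounds than are shown below. What is called first, only, known or untested is meant among the compounds shown, and "the series" means these compounds.

Compound 1 `O=c1nc(N2CCC(c3ccc(CO)cc3)CC2)sc2c([N+](=O)[O-])cc(C(F)(F)F)cc12`: 19600 nM
Compound 2 `O=c1nc(N2CC[C@@H](c3ccccc3)[C@H](O)C2)sc2c([N+](=O)[O-])cc(C(F)(F)F)cc12`: > 93000 nM
Compound 3 `O=c1nc(N2CC[C@@H](c3ccc(F)cc3)[C@H](O)C2)sc2c([N+](=O)[O-])cc(C(F)(F)F)cc12`: 68400 nM

In a toxicity assay on HeLa cells (Homo sapiens) for cytotoxicity, read by colorimetric assay, with a stated time of 72 h (on this read-out higher numbers stand for lower toxicity in this test and lower numbers for higher toxicity in this test), compound 1 gives 19600 nM. Compound 2 sits at the limit of > 93000 nM in this assay, at which 1 of the 3 values shown sits, which is a limit of the assay and not a number. Compound 3 gives 68400 nM, the highest of the two numbers; the nearest number, that of compound 1, lies lower. The only step among these compounds, an at least 1.3-fold lower number from compound 2 to compound 3 (0.13 log units; that floor lies within the scatter), concerns a fluoro on an aromatic carbon and ends against a limit, so its size is only a floor.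

Compound 4 `O=c1nc(N2CC[C@@H](c3ccc(F)cc3)[C@H](CO)C2)sc2c([N+](=O)[O-])cc(C(F)(F)F)cc12` differs from compound 3 by hydroxymethyl in place of hydroxy on a saturated ring carbon. Going by the values given here, no measured step touches this position or this change, so nothing here tells its direction; the one measured step stays within the scatter, and a similar small step is expected here. Compound 4 is therefore expected to give 55000 nM, between 25000 nM and 120000 nM. The step of a 1.2-fold lower number from compound 3 to compound 4 (0.09 log units; within the scatter) that this estimate means is expected to remain within the scatter.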

Compound 4, half-maximal cytotoxic concentration: 35800 nM
For compound 4 the middle estimate is 1.5-fold (0.19 log units) above the measured one, within the range that was stated.
By their numbers in this assay, from the lowest: compounds 1, 4 and 3 (each within the scatter of the next, the first and the last beyond it). At a limit, above all of these: compound 2.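

Going by these compounds alone, the only measured change at this saturated ring carbon, hydroxymethyl in place of hydroxy, comes to a 1.9-fold lower number from compound 3 to compound 4 (0.28 log units; within the scatter) in this assay. Compound 3 and compound 4 therefore cannot be told apart here, so this position, two ring bonds from the ring nitrogen, accepts the added carbon without a change that can be read beyond the scatter, while the count of one hydrogen-bond donor and one hydrogen-bond acceptor stays the same in both groups. Nothing measured here gives a reason for the size of this step.

The compounds shown leave open whether an amine, a carboxylic acid or a longer chain on this ring carbon would move the number beyond the scatter. They also leave open whether removing the oxygen-bearing group altogether would matter on this ring.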